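The source may hold more compounds than are shown below. What is called first, only, known or untested is meant among the compounds shown, and "the series" means these compounds.

Measured in a functional assay on U-937 cells (Homo sapiens) for antiproliferative activity, read by MTT assay, with a stated time of 24 h; a lower number here means a stronger inhibitor, a higher number a weaker inhibitor:
compound 1 `O=C1NC(O)(CCn2cc(C3=CCCCC3)nn2)C(OCc2ccccc2)=C1OCc1ccccc1` — > 100000 nM, a limit of this assay
compound 2 `O=C1NC(O)(CCn2cc(-c3ccccc3)nn2)C(OCc2ccccc2)=C1OCc1ccccc1` — 21500 nM
compound 3 `CC(C)(C)c1ccc(-c2cn(CCC3(O)NC(=O)C(OCc4ccccc4)=C3OCc3ccccc3)nn2)cc1` — 56500 nM

Compound 3 gives the higher of the two numbers in this assay; the step of a 2.6-fold higher number from compound 2 to compound 3 (0.42 log units; beyond the scatter) sets it beyond the scatter from compound 2, while compound 1 sits at the limit (the limit of > 100000 nM in this assay, at which 1 of the 3 values shown sits). Compound 4 `O=C1NC(O)(CCn2cc(Cc3ccccc3)nn2)C(OCc2ccccc2)=C1OCc1ccccc1` carries the change (benzyl in place of 4-(tert-butyl)phenyl on an aromatic carbon). Within the data shown here, no measured step exchanges an aryl for a benzyl at this position; the steps that bear on the substituent of the triazole are an at least 4.6-fold lower number from compound 1 to compound 2 (0.66 log units; beyond the scatter), an at least 1.7-fold lower number from compound 1 to compound 3 (0.24 log units; that floor lies within the scatter) and a 2.6-fold higher number from compound 2 to compound 3 (0.42 log units; beyond the scatter), modest or bounded by the limit. Loss of the tert-butyl points toward compound 2, so a step of a 1.6-fold lower number from compound 3 to compound 4 (0.21 log units; within the scatter) toward a lower number is expected, with wide uncertainty. Compound 4 is estimated at 35000 nM, between 10000 nM and 120000 nM.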

Compound 4, half-maximal inhibitory concentration: > 100000 nM
Compound 4 was reported as a limit (the forecaster's own chance of this, stated with the estimate: 15%); middle value at least 2.8-fold (0.45 log units) from the limit.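

In this assay compound 4 gives > 100000 nM, a limit of the assay, the second compound shown at that limit: the limit of > 100000 nM in this assay, at which 2 of the 4 values shown sit.

Benzyl in place of phenyl at this position gives an at least 4.6-fold higher number from compound 2 to compound 4 (0.66 log units; beyond the scatter), while the change from 4-(tert-butyl)phenyl gives an at least 1.7-fold higher number from compound 3 to compound 4 (0.24 log units; that floor lies within the scatter). Among the compounds shown, only compound 2 and compound 3, with an aromatic ring bonded directly to this carbon, give numbers short of the limit, and the step between compound 1 and compound 4 cannot be read.

Open, from the compounds shown here alone, is whether an amine or a carboxylic acid on the phenyl, or a longer chain ending in phenyl, would give a number short of the limit.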